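Replacing a Methyl with Hydroxy on the Tert-Butyl Group

This account rests on a few compounds, and the source may have more. Where it says the series, first, only, none or still open, it means among the compounds named here.

In a functional assay on HCT-116 cells (Homo sapiens) for inhibition, read by MTT assay, with a stated time of 72 h (on this read-out higher numbers stand for weaker inhibition and lower numbers for stronger inhibition), compound 1 `CC(C)c1ccc(Nc2ccc(C(=O)C(Cl)Cl)cc2[N+](=O)[O-])cc1` gives 700 nM and compound 2 `CC(C)(C)c1ccc(Nc2ccc(C(=O)C(Cl)Cl)cc2[N+](=O)[O-])cc1` gives 500 nM so the two stand level. Their measured step is a 1.4-fold lower number from compound 1 to compound 2 (0.15 log units; within the scatter) and it adds only a methyl in place of hydrogen. Compound 3 `CC(C)(O)c1ccc(Nc2ccc(C(=O)C(Cl)Cl)cc2[N+](=O)[O-])cc1` differs from compound 2 by hydroxy in place of methyl on a saturated chain carbon bound to an aromatic carbon and two saturated chain carbons. Within the data shown here, no measured step involves a hydroxy, so the earlier step guides only loosely. A modest move toward weaker inhibition is expected in this assay with a 2.6-fold higher number from compound 2 to compound 3 (0.41 log units; beyond the scatter) as the estimated step. Compound 3 is estimated at 1300 nM (range 500 nM to 4000 nM).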

Compound 3, half-maximal inhibitory concentration: 1500 nM
Compound 3: the middle estimate sits 1.2-fold (0.06 log units) below what was measured; measured number inside the range.
By their numbers in this assay, from the lowest: compounds 2 and 1 (each within the scatter of the next); then compound 3.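

In this assay, among these compounds, hydrogen and methyl on this carbon stood level, so the hydroxy is the first change here to move the number beyond the scatter, toward weaker inhibition (a 3.0-fold higher number from compound 2 to compound 3 (0.48 log units; beyond the scatter); a 2.1-fold higher number from compound 1 to compound 3 (0.33 log units; beyond the scatter)). The carbon is therefore not indifferent to what it carries, though both steps are modest and inhibition remains. Nothing measured here explains the shift. Still open, from the compounds shown here alone, is whether a methoxy, an amine or a carboxylic acid on this carbon would move the number further, and whether a longer chain would.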